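Hydroxy in place of hydrogen, tested on a second core

The source may report more compounds than this note shows. Statements on the series, on what has been measured and on what is new or still open speak of the compounds shown alone.

Compound 1 `COc1cc2c(/C=C3/C(=O)N(C)c4ccccc43)c(Cl)n(C)c2cc1C` gives 390 nM in a functional assay on cells (Cancer cell lines, Homo sapiens) for inhibition, with a stated time of 48 h; a lower number here means a stronger inhibitor of growth, a higher number a weaker inhibitor of growth. Compound 2 `COc1cc2c(/C=C3/C(=O)N(C)c4ccc(O)cc43)c(Cl)n(C)c2cc1C` differs from it by hydroxy in place of hydrogen on an aromatic carbon, and in this assay compound 2 gives 100 nM, a step of a 3.9-fold lower number from compound 1 to compound 2 (0.59 log units; beyond the scatter). Compound 3 `COc1cc2c(/C=C3/C(=O)N(C)c4ccccc43)c[nH]c2cc1C` rests on a different core; the difference between the two cores is not broken down here. In this assay, for the measured compounds named here, compound 3 gives 4170 nM, the highest number of the three measured so far. Compound 4 `COc1cc2c(/C=C3/C(=O)N(C)c4ccc(O)cc43)c[nH]c2cc1C` applies the same change to the core of compound 3: hydroxy in place of hydrogen on an aromatic carbon, at a place described in the same words as for compound 2. Going by the values given here, a step of about a 3.8-fold lower number from compound 3 to compound 4 (0.58 log units; beyond the scatter) is expected, resting on the single earlier instance a 3.9-fold lower number from compound 1 to compound 2 (0.59 log units; beyond the scatter). Compound 4 is therefore estimated at 1100 nM, within 500 nM to 2500 nM.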

Compound 4, concentration for 50% growth inhibition: 3550 nM
Beside the measured number, compound 4's estimate is 3.2-fold (0.51 log units) below it, and the stated range ends below it.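

On the core of compound 3, hydroxy in place of hydrogen on an aromatic carbon gives in this assay a 1.2-fold lower number from compound 3 to compound 4 (0.07 log units; within the scatter), a step that stays within the scatter. The change therefore does not carry over in size from the core of compound 1 to this second core: the same change on two cores in this assay, a 3.9-fold lower number (0.59 log units; beyond the scatter) from compound 1 to compound 2 and a 1.2-fold lower number (0.07 log units; within the scatter) from compound 3 to compound 4, 3.3-fold (0.52 log units) apart, beyond the scatter of two such steps. With one pair on each core, this shows that the step can differ between cores in this series, but not which feature of the cores accounts for the difference.

As far as these compounds go, it remains open how the change behaves on any further core. From the compounds shown here alone, it is also open whether an amine or a carboxylic acid in place of the hydroxy would give a step of similar size on either core.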